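This account rests on a few compounds, and the source may have more. Where it says the series, first, only, none or still open, it means among the compounds named here.

Measured so far:
Compound 1 `CCC(C)C(NC(=O)NO)C(=O)NCc1ccccc1`; in a functional assay on WI-38 cells (Homo sapiens) for inhibition (on this read-out higher numbers stand for weaker inhibition and lower numbers for stronger inhibition), compound 1 gives > 100000 nM, which is a limit of the assay.
Compound 2 `CCC(C)C(NC(=O)n1nnc2ccccc21)C(=O)NCc1ccccc1`; in this assay compound 2 gives > 100000 nM, likewise a limit of the assay.

Compound 2 therefore stands at the limit of this assay, and compound 1 stands at the same limit, so that the step that the two limits leave unreadable from compound 1 to compound 2 cannot be read; the limit of > 100000 nM in this assay, at which 2 of the 2 values shown sit, is all the record shows for both.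

Compound 3 `CCC(C)C(NC(=O)n1nnc2ccccc21)C(=O)NC1CCCC1` differs from compound 2 in one place: cyclopentyl in place of benzyl on an amide-type nitrogen, on an amide-type nitrogen whose other neighbour is a carbonyl carbon. Within the data shown here, no measured step concerns this position, and the only step on record is unreadable between two limits. There is thus nothing in the numbers to suggest a direction for this change, and it is expected that compound 3 will again return a limit in this assay rather than a number, with an expected step of a number no higher from compound 2 to compound 3 (the limit leaves the size open). The estimate for compound 3 is 100000 nM, with a range from 30000 nM to 300000 nM, and the true outcome is most likely a limit.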

Compound 3, half-maximal inhibitory concentration: > 100000 nM
Compound 3: a limit, no number; the forecaster's own chance of this, stated with the estimate: 85%; the middle value sits exactly at the limit.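

In this assay compound 3 gives > 100000 nM, which is a limit of the assay and not a number. No step can be read from compound 2 to compound 3, and the record shows only this: the limit of > 100000 nM in this assay, at which 3 of the 3 values shown sit.

The compounds shown leave open whether cyclopentyl or benzyl on the amide-type nitrogen makes any difference to inhibition in this assay.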